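Furan in Place of Methylphenyl at the Chain End

This account rests on a few compounds, and the source may have more. Where it says the series, first, only, none or still open, it means among the compounds named here.

Compound 1, `COC1=C(C)C(=O)/C(=C(O)/C=C/c2ccccc2OC)C(=O)C1(C)C`: 1.7 ug/mL
Compound 2, `COC1=C(C)C(=O)/C(=C(O)/C=C/c2ccccc2C)C(=O)C1(C)C`: 2.3 ug/mL

The two measured compounds share one core and differ only in the aromatic group at the end of the chain. In a functional assay on HUVEC cells (Homo sapiens) for cytotoxicity (on this read-out higher numbers stand for an effect only at larger amounts of compound and lower numbers for an effect already at smaller amounts), compound 1 gives 1.7 ug/mL, and compound 2 gives 2.3 ug/mL. The move between them is a 1.4-fold higher number from compound 1 to compound 2 (0.13 log units; within the scatter), so the two numbers cannot be told apart. Compound 2 thus stands at the high end of the two numbers shown, but its gap to compound 1 is within the scatter.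

Compound 3, `COC1=C(C)C(=O)/C(=C(O)/C=C/c2ccco2)C(=O)C1(C)C`, has not yet been measured in this assay. The change is furan-2-yl in place of 2-methylphenyl on a double-bonded chain carbon bound to a double-bonded chain carbon. Among the compounds with values here, the only measured step, a 1.4-fold higher number from compound 1 to compound 2 (0.13 log units; within the scatter), lay within the scatter, and no measured step replaces the whole aromatic group, so the bearing of the data on this change is weak. A change of the whole group could move the number further than the earlier step did, yet nothing in the data points to a direction. Compound 3 is therefore expected near the measured pair, at 2.5 ug/mL with a range from 1 ug/mL to 6 ug/mL. The expected step is a 1.1-fold higher number from compound 2 to compound 3 (0.04 log units; within the scatter), small and uncertain in direction.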

Compound 3, concentration for half-maximal effect: 2.4 ug/mL
Estimate against measurement, compound 3: 1.0-fold (0.02 log units) above, and the stated range covers the measured number.
By their numbers in this assay, from the lowest: compounds 1, 2 and 3 (each within the scatter of the next).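

At this chain end, the whole aromatic group can be exchanged, not just a small substituent on it. In this assay, furan-2-yl, a five-membered ring with one hetero atom, in place of 2-methylphenyl, a six-membered ring of carbon only, gives a 1.0-fold higher number from compound 2 to compound 3 (0.02 log units; within the scatter) and leaves the two numbers indistinguishable, while furan-2-yl in place of 2-methoxyphenyl gives a 1.4-fold higher number from compound 1 to compound 3 (0.15 log units; within the scatter) and likewise stays inside the usual spread of repeat measurements. Neither the smaller ring nor the added hydrogen-bond acceptor therefore appears as a measurable difference in these three compounds, and no supporting measurement is available to explain this flat result.

As far as these compounds go, all three end groups are aromatic rings with no net charge, so it remains open whether the number would stay this flat with a different kind of group at this place, such as an amine, a carboxylic acid or a longer chain. A single read-out on one cell type also leaves open whether compound 3 would match compound 2 in any other test.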